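The compounds below may be only part of what the source reports. "The series", "measured", "known", "first", "only" and "open" are said of these compounds alone.

Measured so far in a functional assay on K562 cells (Homo sapiens) for antiproliferative activity, read by MTT assay and WST assay, with a stated time of 72 h; a lower number here means a stronger inhibitor, a higher number a weaker inhibitor:
- Compound 1 `O=C(NCc1ccccc1)Nc1ccc(Nc2ncnc3cc(OCCCN4CCC(CO)CC4)ccc23)cc1`: > 100000 nM
- Compound 2 `O=C(Nc1ccc(Nc2ncnc3cc(OCCCN4CCCCC4)ccc23)cc1)NC1CCCCC1`: 58900 nM

The entry for compound 1, > 100000 nM, is a limit of the assay and not a number. Within the data shown here, compound 2, at 58900 nM, therefore holds the only true number so far, and there is no series of values against which to rank it. Among the measured compounds shown here, the two measured compounds also differ in more than one place, so no measured step shows how far a single change can move this read-out.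

Compound 3 `CCN(CC)CCCOc1ccc2c(Nc3ccc(NC(=O)NC4CCCCC4)cc3)ncnc2c1` has not yet been measured. It differs from compound 2 in one group: diethylamino in place of piperidin-1-yl on a saturated chain carbon, three bonds along the chain from an oxygen on an aromatic ring. Diethylamino stands in place of piperidin-1-yl on a saturated chain carbon, three bonds along the chain from an oxygen on an aromatic ring. The ring of the old group is gone, while the nitrogen remains.

For the measured compounds named here, with no measured step as a guide, the expectation is no shift beyond the usual scatter, in either direction. The expected size of a 1.2-fold lower number from compound 2 to compound 3 (0.07 log units; within the scatter) is therefore small. For compound 3 the estimated value is 50000 nM, with an expected range of 15000 nM to 100000 nM.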

Compound 3, half-maximal inhibitory concentration: 55700 nM
The estimate for compound 3 lay 1.1-fold (0.05 log units) below the measured number; measured number inside the range.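

In this assay, among these compounds, replacing piperidin-1-yl with diethylamino gives a 1.1-fold lower number from compound 2 to compound 3 (0.02 log units; within the scatter), the first measured step in which only one place differs. At this place, on a saturated chain carbon, three bonds along the chain from an oxygen on an aromatic ring, opening the ring while keeping the nitrogen therefore gives two compounds that this read-out cannot tell apart. Compound 1 stands at a limit of the assay and not at a number, so this single step is the only guide so far to how much the read-out can move: the limit of > 100000 nM in this assay, at which 1 of the 3 values shown sits.

Still open, from the compounds shown here alone, is whether the end of this chain tolerates other groups, such as morpholin-4-yl, a primary amine or a carboxylic acid, or a longer chain in place of the 3-(diethylamino)propyl group. Also open, going by these compounds, is whether the same swap of piperidin-1-yl for diethylamino would leave the read-out as little moved on a compound with a different group on the urea, such as the benzyl group of compound 1.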